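Glycine for Alanine in a Farnesyl Thioether Furoxan Ester Series

The source may hold more compounds than are shown below. What is called first, only, known or untested is meant among the compounds shown, and "the series" means these compounds.

Three compounds were measured in a functional assay on MDA-MB-231 cells (Homo sapiens) for cytotoxicity, read by MTT assay, with a stated time of 48 h; a lower number here means a stronger inhibitor, a higher number a weaker inhibitor. Compound 1 `CC(C)=CCC/C(C)=C/CC/C(C)=C/CSc1ccccc1C(=O)N[C@@H](C)C(=O)OCC#CCOc1no[n+]([O-])c1S(=O)(=O)c1ccccc1` gives 1010 nM, the lowest of the three numbers. Compound 2 `CC(C)=CCC/C(C)=C/CC/C(C)=C/CSc1ccccc1C(=O)N[C@@H](C)C(=O)OC(C)CCOc1no[n+]([O-])c1S(=O)(=O)c1ccccc1` gives 5050 nM, and compound 3 `CC(C)=CCC/C(C)=C/CC/C(C)=C/CSc1ccccc1C(=O)NCC(=O)OC(C)CCOc1no[n+]([O-])c1S(=O)(=O)c1ccccc1` gives 7260 nM. The difference between the core of compound 1 and the core of compound 2 is not broken down here.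

Compound 3 differs from compound 2 in one place: hydrogen in place of methyl on a saturated chain carbon bound to an amide-type nitrogen and a carbonyl carbon. This change gave a 1.4-fold higher number from compound 2 to compound 3 (0.16 log units; within the scatter). Compound 4 `CC(C)=CCC/C(C)=C/CC/C(C)=C/CSc1ccccc1C(=O)NCC(=O)OCC#CCOc1no[n+]([O-])c1S(=O)(=O)c1ccccc1` is not yet measured; it differs from compound 1 by the same change in the same place: hydrogen in place of methyl on a saturated chain carbon bound to an amide-type nitrogen and a carbonyl carbon.

Because a 1.4-fold higher number from compound 2 to compound 3 (0.16 log units; within the scatter) stayed within the scatter, the step for compound 4 is expected to be small as well. Among the compounds with values here, the expected step is a 1.4-fold higher number from compound 1 to compound 4 (0.14 log units; within the scatter), and it rests only on the single measured pair. Compound 4 is therefore estimated at 1400 nM in this assay, with a range from 600 nM to 3500 nM, a range that stays well apart from the numbers of compound 2 and compound 3.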

Compound 4, half-maximal inhibitory concentration: 7230 nM
Estimate against measurement, compound 4: 5.2-fold (0.71 log units) below; the measured number lies above the stated range.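

In this assay, hydrogen in place of methyl on a saturated chain carbon bound to an amide-type nitrogen and a carbonyl carbon gave a 7.2-fold higher number from compound 1 to compound 4 (0.85 log units; beyond the scatter), a step beyond the scatter, whereas the earlier step on the other core stayed within it. The change therefore did not carry over at the same size from one core to the other: the same change on two cores in this assay, a 1.4-fold higher number (0.16 log units; within the scatter) from compound 2 to compound 3 and a 7.2-fold higher number (0.85 log units; beyond the scatter) from compound 1 to compound 4, 5.0-fold (0.70 log units) apart, beyond the scatter of two such steps. This shows that, in these two pairs, the size of the step differs with the core, but it does not show why, and two pairs give no rule for predicting the step on any further core.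

The compounds shown leave open whether an ethyl group or a longer chain in place of the methyl on that same carbon would give a number nearer to that of the methyl compounds or of the hydrogen compounds. They also leave open whether a third core would show the small step or the large one.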